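This account rests on a few compounds, and the source may have more. Where it says the series, first, only, none or still open, it means among the compounds named here.

Measured so far in a functional assay on HL-60 cells (Homo sapiens) for inhibition, read by CCK-8 assay, with a stated time of 48 h; a higher number here means a weaker inhibitor, a lower number a stronger inhibitor:
compound 1 `Cc1cc(C)cc(NC(=O)NCCNS(=O)(=O)c2ccc(-c3ccccc3OCc3ccccc3)s2)c1`: 2200 nM
compound 2 `Cc1cc(C)cc(NC(=O)NCCNS(=O)(=O)c2ccc(-c3ccccc3OCc3cccc(O)c3)s2)c1`: > 20000 nM
compound 3 `Cc1cc(C)cc(NC(=O)NCCNS(=O)(=O)c2ccc(-c3ccccc3Oc3ccc([N+](=O)[O-])c([N+](=O)[O-])c3)s2)c1`: 9100 nM

Compound 1 gives the lowest number of the two numbers shown, with compound 3 nearest: a 4.1-fold higher number from compound 1 to compound 3 (0.62 log units; beyond the scatter). For compound 2 the value is a limit of this assay and not a number. Both measured steps from compound 1 concern the oxygen on the aromatic ring of the shared core: an at least 9.0-fold higher number from compound 1 to compound 2 (0.95 log units; beyond the scatter) and a 4.1-fold higher number from compound 1 to compound 3 (0.62 log units; beyond the scatter); between the other two, an at least 2.1-fold lower number from compound 2 to compound 3 (0.34 log units; beyond the scatter).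

Compound 4 `COc1cccc(NC(=O)NCCNS(=O)(=O)c2ccc(-c3ccccc3OCc3ccccc3)s2)c1` has not yet been measured. It differs from compound 1 at the other end of the core: 3-methoxyphenyl in place of 3,5-dimethylphenyl on an amide-type nitrogen. Among the measured compounds shown here, none of the measured steps touches the aryl group on the amide-type nitrogen, so no step bears directly on this change; the measured steps only show how far the numbers can move with one change. With no direct guide, a step within the scatter is expected, taken with a wide range: a 1.4-fold higher number from compound 1 to compound 4 (0.13 log units; within the scatter) is the estimated step. Compound 4 is therefore expected to give about 3000 nM in this assay, estimated between 900 nM and 10000 nM.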

Compound 4, half-maximal inhibitory concentration: 1700 nM
Beside the measured number, compound 4's estimate is 1.8-fold (0.25 log units) above it, within the range that was stated.
By their numbers in this assay, from the lowest: compounds 4 and 1 (each within the scatter of the next); then compound 3. At a limit, above all of these: compound 2.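

In this assay, the aryl group on the amide-type nitrogen is changed with the rest of the structure held constant, and the exchange gives a 1.3-fold lower number from compound 1 to compound 4 (0.11 log units; within the scatter), so 3-methoxyphenyl and 3,5-dimethylphenyl cannot be told apart at this position. The exchange keeps the 8 heavy atoms and the six-membered aromatic ring and goes from 0 hydrogen-bond acceptors to 1, yet this step stays within the scatter, whereas the two changes on the oxygen on the aromatic ring of the shared core, an at least 9.0-fold higher number from compound 1 to compound 2 (0.95 log units; beyond the scatter) and a 4.1-fold higher number from compound 1 to compound 3 (0.62 log units; beyond the scatter), lie beyond it. No measured property among the data shown bears on this step at the amide-type nitrogen.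

Open, on these data alone, is whether this position stays as flat with an amine or a carboxylic acid in place of the methoxy group, or with a cyclohexyl group in place of the whole aryl ring. Also open, as far as these compounds go, is whether the 3-methoxyphenyl exchange stays within the scatter when the oxygen carries 3-hydroxybenzyl or 3,4-dinitrophenyl rather than benzyl.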